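A Methyl Added to the Saturated Ring of Compound 1

The source may report more compounds than this note shows. Statements on the series, on what has been measured and on what is new or still open speak of the compounds shown alone.

Of the compounds shown here, three have been measured in an assay on Sf21 cells for inhibition of cytochrome c oxidase subunit 2 (Homo sapiens), read by spectrophotometry, with a stated time of 5 min; on this read-out higher numbers stand for weaker inhibition and lower numbers for stronger inhibition. Compound 1, `O=C1CCCCC1C1CC(=O)N(Cc2ccccc2)C1=O`, gives 20000 nM. Compound 2, `NS(=O)(=O)c1ccc(N2C(=O)CC(CC(=O)c3ccccn3)C2=O)cc1`, gives 8940 nM, and compound 3, `O=C1CCCCC1C1CC(=O)N(c2ccc(Br)cc2)C1=O`, gives 113000 nM. Among these three numbers compound 1 holds the second highest; compound 2 sits lower than it, and the single one-place step recorded, a 5.7-fold higher number from compound 1 to compound 3 (0.75 log units; beyond the scatter), moves the number upward.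

Compound 4, `CC1CCC(=O)C(C2CC(=O)N(Cc3ccccc3)C2=O)C1`, is not yet measured. It differs from compound 1 in one place: methyl in place of hydrogen on a saturated ring carbon. Within the data shown here, no measured step touches this part of the core of compound 1; the only recorded step concerns the group on the amide-type nitrogen and says nothing about a methyl on the six-membered ring. With nothing to lean on, the expectation is no step beyond the scatter. Compound 4 is therefore estimated at 20000 nM, within a range from 8000 nM to 50000 nM. This estimate means an expected step of no change at the digits printed from compound 1 to compound 4 (within the scatter).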

Compound 4, half-maximal inhibitory concentration: 21900 nM
Compound 4: the middle estimate sits 1.1-fold (0.04 log units) below what was measured, within the range that was stated.
By their numbers in this assay, from the lowest: compound 2; then compounds 1 and 4 (each within the scatter of the next); then compound 3.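

Among these compounds, the one earlier step concerned the group on the amide-type nitrogen, so this is the first reading on the six-membered ring: methyl in place of hydrogen on a saturated ring carbon, two ring bonds from the ring atom that bears a large group, gives a 1.1-fold higher number from compound 1 to compound 4 (0.04 log units; within the scatter). With compound 1 as the parent, this ring carbon can therefore carry a methyl with no change that stands out from the scatter. Nothing available explains this result.

As far as these compounds go, it remains open whether an ethyl or phenyl group, or an amine or hydroxyl group, at this ring carbon would also leave the number in place. Also open, from the compounds shown here alone, is whether the methyl would give a similar result with the 4-bromophenyl group of compound 3 on the nitrogen.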